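Stripping the Methylsulfonyl Group from Compound 2

This account rests on a few compounds, and the source may have more. Where it says the series, first, only, none or still open, it means among the compounds named here.

The study measures an in vitro assay on BL21-DE3 cells for inhibition of Deoxyuridine 5'-triphosphate nucleotidohydrolase, mitochondrial (Homo sapiens); on this read-out higher numbers stand for weaker inhibition and lower numbers for stronger inhibition. Going by the values given here, compound 1, `CCCCC(=O)NCC1OC(n2ccc(=O)[nH]c2=O)CC1O`, is one of two compounds measured so far. In this assay compound 1 gives > 1000000 nM, which is a limit of the assay rather than a number. Compound 2, `CS(=O)(=O)NCC1OC(n2ccc(=O)[nH]c2=O)CC1O`, carries a methylsulfonyl group where compound 1 carries a butylcarbonyl group. In this assay compound 2 gives > 1000000 nM, again a limit of the assay and not a number. The step that the two limits leave unreadable from compound 1 to compound 2 therefore cannot be read, because of the limit of > 1000000 nM in this assay, at which 2 of the 2 values shown sit. Compound 2 thus stands at the limit, with no number that would set it apart from compound 1.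

Compound 3, `NCC1OC(n2ccc(=O)[nH]c2=O)CC1O`, differs from compound 2 by hydrogen in place of methylsulfonyl on an amine nitrogen. Among the compounds with values here, no measured step bears on this change, since the only step recorded is unreadable. With both measured compounds sitting at the limit, there is no basis for expecting a readable gain. The expected step is a number no higher from compound 2 to compound 3 (the limit leaves the size open), meaning compound 3 is expected to remain at the limit. For compound 3 in this assay the estimate is 1000000 nM, with a range from 100000 nM to 10000000 nM.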

Compound 3, inhibition constant: > 1000000 nM
Compound 3 ended at the assay's limit; the forecaster's own chance of this, stated with the estimate: 85%; the middle value lies on the limit itself.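

Compound 1, compound 2 and compound 3 all sit at a limit of this assay rather than at a number, so no step among these three compounds can be read: the limit of > 1000000 nM in this assay, at which 3 of the 3 values shown sit.

The compounds shown leave open whether any group on this amine nitrogen gives a readable number, and how hydrogen, methylsulfonyl and butylcarbonyl truly compare.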